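A few compounds are considered here, and "the series" means these few. Any claim that something is new, unique, unknown or untested is made for them only; others in the source may bear on it.

Compound 1 `CS(=O)(=O)c1ccc(-c2nc3ccccn3c2Sc2ccccc2)cc1` is one of three close relatives tested in a functional assay on SK-MEL-28 cells (Homo sapiens) for inhibition, read by MTT assay, with a stated time of 48 h; a lower number here means a stronger inhibitor, a higher number a weaker inhibitor. In this assay compound 1 gives 61900 nM, the lower of the two numbers obtained, while compound 3 `Clc1ccc2nc(-c3ccccc3)c(Sc3ccccc3)n2c1` gives 76900 nM, which sits within the scatter of it. Compound 2 `c1ccc(Sc2c(-c3cccc4ccccc34)nc3ccccn23)cc1` reaches only a limit in this assay, > 100000 nM; (the limit of > 100000 nM in this assay, at which 1 of the 3 values shown sits). Compound 4 `Clc1ccc(-c2nc3ccccn3c2Sc2ccccc2)cc1` has not yet been measured. It differs from compound 1 by chloro in place of methylsulfonyl on an aromatic carbon. Going by the values given here, no measured pair of compounds shows a change of this kind, so no step size can be borrowed from the data; a change within the scatter, or at most a modest one in either direction, is expected. Compound 4 is estimated at 50000 nM, between 18000 nM and 140000 nM, an expected step of a 1.2-fold lower number from compound 1 to compound 4 (0.09 log units; within the scatter).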

Compound 4, half-maximal inhibitory concentration: 73100 nM
Estimate against measurement, compound 4: 1.5-fold (0.16 log units) below; measured number inside the range.
By their numbers in this assay, from the lowest: compounds 1, 4 and 3 (each within the scatter of the next). At a limit, above all of these: compound 2.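

In this assay, chloro in place of methylsulfonyl on this aromatic carbon, para to a large group, gives a 1.2-fold higher number from compound 1 to compound 4 (0.07 log units; within the scatter). The two hydrogen-bond acceptors of methylsulfonyl can therefore go without a change that stands out from the scatter, and a group of one heavy atom serves here as well as the larger one. Still open, as far as these compounds go, is whether an amine or a carboxylic acid at this place would move the number beyond the scatter. No measurement shown bears on why compound 1 and compound 4 read alike.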